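Solubility notes: methyl in place of chloro on the core

The source may hold more compounds than are shown below. What is called first, only, known or untested is meant among the compounds shown, and "the series" means these compounds.

Values measured so far in a physicochemical assay for solubility, at pH 7.4; on this read-out lower numbers stand for lower solubility and higher numbers for higher solubility:
- compound 1 `CC(C)Nc1nc(NCc2ccco2)c2ccccc2n1` gives >= 30000 nM, a limit of the assay
- compound 2 `CC(C)Nc1nc(NCc2ccco2)c2cccc(Cl)c2n1` gives <= 5000 nM, a limit of the assay
- compound 3 `CC(C)Nc1nc(NCc2ccco2)c2cc(Cl)ccc2n1` gives <= 20000 nM, a limit of the assay

None of the three values is a true number; each is a limit. Compound 3 therefore stands only at a ceiling in this assay (the limit of <= 20000 nM in this assay, at which 1 of the 3 values shown sits), and the two other compounds sit at limits as well (the limit of <= 5000 nM in this assay, at which 1 of the 3 values shown sits, (the limit of >= 30000 nM in this assay, at which 1 of the 3 values shown sits)).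

Compound 4 `Cc1ccc2nc(NC(C)C)nc(NCc3ccco3)c2c1` differs from compound 3 by methyl in place of chloro on an aromatic carbon. Going by the values given here, no measured step exchanges methyl for chloro. The steps that touch the same kind of change are an at least 6.0-fold lower number from compound 1 to compound 2 (0.77 log units; beyond the scatter) and an at least 1.5-fold lower number from compound 1 to compound 3 (0.17 log units; that floor lies within the scatter), both chloro in place of hydrogen, and both bounded by limits on either side, so their true size is open. A swap of one substituent for another at the same place on the shared core is expected to move this assay less than introducing a substituent did, so the step that the limit leaves unreadable from compound 3 to compound 4 is estimated to lie within the scatter. Compound 4 is expected to give 15000 nM in this assay, in the range 5000 nM to 40000 nM.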

Compound 4, solubility: <= 20000 nM
Compound 4 ended at the assay's limit (the forecaster's own chance of this, stated with the estimate: 45%); the middle value lies beyond the limit too.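

In this assay, compound 3 and compound 4 stand at one and the same limit of the assay, so neither the size nor the direction of methyl in place of chloro at this position can be read: the limit of <= 20000 nM in this assay, at which 2 of the 4 values shown sit. Methyl in place of hydrogen at this position gives an at least 1.5-fold lower number from compound 1 to compound 4 (0.17 log units; that floor lies within the scatter), the same floor as chloro in place of hydrogen at this position, an at least 1.5-fold lower number from compound 1 to compound 3 (0.17 log units; that floor lies within the scatter), so a second substituent here still yields no step that is firmly beyond the scatter. Going by these compounds alone, the only step printed as beyond the scatter remains the one with chloro at a different place on the shared core, an at least 6.0-fold lower number from compound 1 to compound 2 (0.77 log units; beyond the scatter).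

From the compounds shown here alone, with limits at both ends, the true size of every step from compound 1 stays open, as does whether methyl and chloro differ at all at this position. Also open, going by these compounds, is whether an amine or a carboxylic acid in place of the methyl of compound 4 would bring this assay to a true number rather than a limit.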